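The source may report more compounds than this note shows. Statements on the series, on what has been measured and on what is new or still open speak of the compounds shown alone.

Of the compounds shown here, three have been measured in a functional assay on A549 cells (Homo sapiens) for antiproliferative activity, read by MTT assay, with a stated time of 72 h; on this read-out lower numbers stand for stronger inhibition and higher numbers for weaker inhibition.
Compound 1, `COc1cc(-n2cnc3ccc(-c4ccc(C)cc4F)cc32)cc(OC)c1OC`, gives > 10000 nM, which is a limit of the assay.
Compound 2, `COc1cc(-n2cnc3ccc(-c4ccc(C(F)(F)F)cc4)cc32)cc(OC)c1OC`, gives 3390 nM.
Compound 3, `COc1cc(-n2cnc3ccc(-c4cccc(C)c4C)cc32)cc(OC)c1OC`, gives 9250 nM.

Compound 3 gives the highest of the two numbers shown, with one further value being only a limit. The gap to the nearest number is a 2.7-fold higher number from compound 2 to compound 3 (0.44 log units; beyond the scatter). Compound 4, `COc1cccc(-c2ccc3ncn(-c4cc(OC)c(OC)c(OC)c4)c3c2)c1`, differs from compound 3 in one place: 3-methoxyphenyl in place of 2,3-dimethylphenyl on an aromatic carbon. For the measured compounds named here, no measured step exchanges a 2,3-dimethylphenyl for a 3-methoxyphenyl. The steps that touch the same aromatic carbon, an at least 1.0-fold lower number from compound 1 to compound 3 (0.03 log units; that floor lies within the scatter) and a 2.7-fold higher number from compound 2 to compound 3 (0.44 log units; beyond the scatter), were modest or inside the scatter, so only a small shift, if any, is expected in this assay. Compound 4 is therefore estimated at 8000 nM, between 3000 nM and 25000 nM. That estimate would mean a 1.2-fold lower number from compound 3 to compound 4 (0.06 log units; within the scatter).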

Compound 4, half-maximal inhibitory concentration: 3180 nM
Compound 4: middle estimate off by 2.5-fold (0.40 log units), on the high side; the measured number falls inside the stated range.
By their numbers in this assay, from the lowest: compounds 4 and 2 (each within the scatter of the next); then compound 3. At a limit, above all of these: compound 1.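

In this assay, exchanging 2,3-dimethylphenyl for 3-methoxyphenyl on this aromatic carbon gives a 2.9-fold lower number from compound 3 to compound 4 (0.46 log units; beyond the scatter), a larger shift than the small one expected. The 3-methoxyphenyl and 4-(trifluoromethyl)phenyl groups are not separated, with a 1.1-fold lower number from compound 2 to compound 4 (0.03 log units; within the scatter), so two quite different substituents read alike here. The remaining step, an at least 3.1-fold lower number from compound 1 to compound 4 (0.49 log units; beyond the scatter), rests on a limit and not a number: the limit of > 10000 nM in this assay, at which 1 of the 4 values shown sits.

The compounds shown leave open whether the methoxy group itself or the loss of the two methyl groups drives the step, and unsubstituted phenyl is not among them. From the compounds shown here alone, how an amine or a carboxylic acid on this ring would read also remains open.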